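Phenylsulfonyl on the ring amine of compound 3

The compounds below may be only part of what the source reports. "The series", "measured", "known", "first", "only" and "open" are said of these compounds alone.

In a functional assay on SMMC-7721 cells (Homo sapiens) for cytotoxicity, read by MTT assay, with a stated time of 24 h (on this read-out lower numbers stand for stronger inhibition and higher numbers for weaker inhibition), compound 1 `COc1ccc(/C=C2\CN(C)C/C(=C\c3cccnc3)C2=O)c(OC)c1OC` gives 13700 nM and compound 2 `CN1C/C(=C\c2cccnc2)C(=O)/C(=C/c2ccccc2F)C1` gives 5420 nM. Compound 3 `O=C1/C(=C/c2cccnc2)CNC/C1=C\c1ccccc1F` gives > 20000 nM, which is a limit and not a number. That places compound 3 at the limit of > 20000 nM in this assay, at which 1 of the 3 values shown sits. Compound 4 `O=C1/C(=C/c2cccnc2)CN(S(=O)(=O)c2ccccc2)C/C1=C\c1ccccc1F` follows from compound 3 by phenylsulfonyl in place of hydrogen on an amine nitrogen in a ring. Within the data shown here, the one measured step at this nitrogen is an at least 3.6-fold higher number from compound 2 to compound 3 (0.56 log units; beyond the scatter), with hydrogen in place of methyl, and it is at least modest. Methyl is a far smaller group than phenylsulfonyl, so that step guides the direction only loosely: substitution on the nitrogen is expected to lower the number. The expected change is an at least 2.8-fold lower number from compound 3 to compound 4 (0.45 log units; beyond the scatter). For compound 4 the estimate is 7000 nM, with an expected range of 1800 nM to 20000 nM.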

Compound 4, half-maximal inhibitory concentration: 19100 nM
Estimate against measurement, compound 4: 2.7-fold (0.44 log units) below, within the range that was stated.
By their numbers in this assay, from the lowest: compound 2; then compounds 1 and 4 (each within the scatter of the next). At a limit, above all of these: compound 3.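

Phenylsulfonyl on this ring amine gives a number that can be read in this assay, but the change from the free amine is only an at least 1.0-fold lower number from compound 3 to compound 4 (0.01 log units; that floor lies within the scatter). This step can be read only as a floor because compound 3 stands at a limit: the limit of > 20000 nM in this assay, at which 1 of the 4 values shown sits. Against methyl on the same nitrogen, the change is a 3.5-fold higher number from compound 2 to compound 4 (0.55 log units; beyond the scatter), so of the three groups at this position, methyl gives the lowest number.

As far as these compounds go, it remains open whether the sulfonyl link or the phenyl ring sets this number. Methylsulfonyl, acetyl or benzyl on this nitrogen would address that.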